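A few compounds are considered here, and "the series" means these few. Any claim that something is new, unique, unknown or untested is made for them only; others in the source may bear on it.

Compound 2 `COc1ccc2nccc(C(=O)NCCC3CCN(S(=O)(=O)NC(=O)NC[C@@H]4C[C@@H]5C=C[C@@H]4C5)CC3)c2c1` stands lowest of the two numbers measured in a functional assay on the whole organism (blood) with Rattus norvegicus as the target, with stated times of 24 h and 1 h, at a dose of 5 mg/kg by the intraperitoneal route (on this read-out lower numbers stand for a weaker effect and higher numbers for a stronger effect at the one dose given), where compound 2 gives 10%. Its nearest neighbour is compound 1 `O=C(NC[C@@H]1C[C@@H]2C=C[C@@H]1C2)NS(=O)(=O)N1CCC(CCNC(=O)c2cc(Cl)ccn2)CC1`, and in this assay compound 1 gives 32%. Compound 3 `Cn1cc(C(=O)NCCC2CCN(S(=O)(=O)NC(=O)NC[C@@H]3C[C@@H]4C=C[C@@H]3C4)CC2)c(=O)n(C)c1=O` differs from compound 2 in one place: a group of 10 heavy atoms (6 carbon, 2 nitrogen, 2 oxygen; one six-membered aromatic ring with 2 hetero atoms) in place of a group of 12 heavy atoms (10 carbon, 1 nitrogen, 1 oxygen; one six-membered aromatic ring of carbon only, one six-membered aromatic ring with 1 hetero atom), on a carbonyl carbon. Among the measured compounds shown here, the only measured step that bears on this swaps the group on the same carbonyl carbon, with a number 22 percentage points lower from compound 1 to compound 2 (beyond the scatter); that step shows the group there matters, but it involves different groups, so the direction for compound 3 stays uncertain. For compound 3 a small rise is expected, a number 6 percentage points higher from compound 2 to compound 3 (within the scatter). Compound 3 is estimated at 16%, within 0% to 38%.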

Compound 3, a percentage reported as activity, at one dose (the size of the read-out at that dose, not a potency): 23%
Beside the measured number, compound 3's estimate is 7 percentage points below it; low and high end bracket the measured number.
By their numbers in this assay, from the lowest: compound 2; then compounds 3 and 1 (each within the scatter of the next).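

In this assay, the group on the carbonyl carbon can push the number up as well as down: the dimethylated ring with two carbonyls in place of 6-methoxyquinolin-4-yl gives a number 13 percentage points higher from compound 2 to compound 3 (beyond the scatter) in this series. The same ring in place of 4-chloropyridin-2-yl gives a number 9 percentage points lower from compound 1 to compound 3 (within the scatter), so two quite different six-membered aromatic rings read alike here, and only 6-methoxyquinolin-4-yl stands apart from both. From the compounds shown here alone, how a non-aromatic group such as cyclohexyl, or a simple methyl, would read on this carbonyl carbon stays open. Nothing measured here explains why these groups differ.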